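The source may report more compounds than this note shows. Statements on the series, on what has been measured and on what is new or still open speak of the compounds shown alone.

Measured in a functional assay on NCI-H460 cells (Homo sapiens) for cytotoxicity, read by sulforhodamine B assay, with a stated time of 24 h; on this read-out higher numbers stand for weaker inhibition and lower numbers for stronger inhibition:
- compound 1 `CC(=O)SCCCCC[C@H](NC(=O)[C@H]1CCC(=O)N1)C(=O)Nc1ccccc1`, 70 nM
- compound 2 `CC(=O)SCCCCC[C@H](NC(=O)[C@@H]1CC(=O)N1)C(=O)Nc1ccccc1`, 50 nM
- compound 3 `CCOC(=S)OCCCCC[C@H](NC(=O)[C@@H]1CCCC(=O)N1)C(=O)Nc1ccccc1`, 510 nM

Compound 1 holds the second highest of the three numbers, and compound 3 holds the highest. Compound 4 `CC(=O)SCCCCC[C@H](NC(=O)[C@H]1CCC(=O)N1)C(=O)Nc1cccc(C)c1` differs from compound 1 by methyl in place of hydrogen on an aromatic carbon, which is methyl in place of hydrogen on an aromatic carbon, meta to a large group. Among the measured compounds shown here, the only measured step, a 1.4-fold lower number from compound 1 to compound 2 (0.15 log units; within the scatter), has 4-oxoazetidin-2-yl in place of 5-oxopyrrolidin-2-yl on a carbonyl carbon. It leaves the aromatic ring unchanged, so it bears only indirectly. For the measured compounds named here, no measured step tests a methyl group on that ring, and no step beyond the scatter is expected in this assay in either direction. The estimated step, no change at the digits printed from compound 1 to compound 4 (within the scatter), is expected to remain within the scatter. Compound 4 is expected at 70 nM, with an estimated range of 30 nM to 170 nM.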

Compound 4, half-maximal inhibitory concentration: 40 nM
The estimate for compound 4 lay 1.8-fold (0.24 log units) above the measured number; low and high end bracket the measured number.
By their numbers in this assay, from the lowest: compounds 4, 2 and 1 (each within the scatter of the next); then compound 3.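

Phenyl to 3-methylphenyl gives a 1.8-fold lower number from compound 1 to compound 4 (0.24 log units; within the scatter) in this assay, so this aromatic carbon accepts one added carbon without a step beyond the scatter. Among the compounds shown here, the only earlier step changed the group on the carbonyl carbon, so this is the sole reading from the aromatic ring. No data bear on the reason for this result.

From the compounds shown here alone, whether an amine, a carboxylic acid or a longer chain at this aromatic carbon would also stay within the scatter remains open. So does the outcome of a methyl on another carbon of that ring.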